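Methyl to Methoxy on Two Related Cinnamamide Thiadiazoles

This account rests on a few compounds, and the source may have more. Where it says the series, first, only, none or still open, it means among the compounds named here.

Of the compounds shown here, three have been measured in a functional assay on MCF7 cells (Homo sapiens) for antiproliferative activity, read by MTT assay, with a stated time of 48 h; a higher number here means a weaker inhibitor, a lower number a stronger inhibitor. Compound 1 `COc1ccc(/C=C/C(=O)Nc2nnc(-c3ccccc3)s2)cc1` gives 0.83 ug/mL in this assay. Compound 2 `Cc1ccc(/C=C/C(=O)Nc2nnc(-c3ccccc3)s2)cc1` gives 1.23 ug/mL. Compound 3 `Cc1ccc(-c2nnc(NC(=O)/C=C/c3ccccc3)s2)cc1` gives 1.19 ug/mL; compound 3 and compound 2 hold the same atoms joined differently, and the difference between the two cores is not broken down here. Compound 3 and compound 2 differ by a gap that lies within the scatter, and so do compound 3 and compound 1.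

For the measured compounds named here, the one single-point change that has been measured is methoxy in place of methyl on an aromatic carbon, which gave a 1.5-fold lower number from compound 2 to compound 1 (0.17 log units; within the scatter). Compound 4 `COc1ccc(-c2nnc(NC(=O)/C=C/c3ccccc3)s2)cc1` is not yet measured; it differs from compound 3 by methoxy in place of methyl on an aromatic carbon. The two changes read the same word for word, including the place at which they occur, so the change from compound 3 to compound 4 is the same change already seen from compound 2 to compound 1, now made on the core of compound 3.

Going by the values given here, with only one earlier example, the expectation rests on that one step. Because the change from compound 2 to compound 1 gave a 1.5-fold lower number from compound 2 to compound 1 (0.17 log units; within the scatter), a step of about the same size is expected from compound 3 to compound 4, namely a 1.4-fold lower number from compound 3 to compound 4 (0.15 log units; within the scatter). Compound 4 is therefore expected to give about 0.85 ug/mL in this assay, likely between 0.45 ug/mL and 1.6 ug/mL, a number within the scatter of compound 3.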

Compound 4, half-maximal inhibitory concentration: 0.78 ug/mL
Compound 4: middle estimate off by 1.1-fold (0.04 log units), on the high side; low and high end bracket the measured number.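

Carried to the second core, methoxy in place of methyl on an aromatic carbon gave, in this assay, a 1.5-fold lower number from compound 3 to compound 4 (0.18 log units; within the scatter). Set beside the earlier case, the change reads alike on the two cores: the same change on two cores in this assay, a 1.5-fold lower number (0.17 log units; within the scatter) from compound 2 to compound 1 and a 1.5-fold lower number (0.18 log units; within the scatter) from compound 3 to compound 4, 1.0-fold (0.01 log units) apart, within the scatter of two such steps. This shows that the two steps agree with each other, but each one lies within the scatter on its own, so it does not show that this change moves the number in a real way on either core, and two cores are too few to support a rule for the whole series.

The compounds shown leave open whether a step large enough to stand clear of the scatter could be found at this place, for instance with an amine, a carboxylic acid, a longer chain such as butoxy, or a halogen such as chlorine, and whether such a step would then also carry from one core to the other. They also leave open what happens when a methyl or methoxy group is present on both aromatic rings of one compound, and whether the agreement between the two cores would hold in any other assay.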